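The compounds below may be only part of what the source reports. "The series", "measured", "known", "first", "only" and "open" are said of these compounds alone.

In a functional assay on DU-145 cells (Homo sapiens) for inhibition, read by MTT assay, with a stated time of 24 h (on this read-out lower numbers stand for stronger inhibition and higher numbers for weaker inhibition), compound 1, `CCOC(=O)C1=Cc2ccccc2OC1(OCc1cn(CC(=O)Nc2ccc(C)cc2)nn1)C(F)(F)F`, gives only the limit > 150000 nM, not a number. Compound 3, `CCOC(=O)C1=Cc2ccccc2OC1(OCc1cn(-c2cccc(C(F)(F)F)c2)nn1)C(F)(F)F`, likewise gives only the limit > 150000 nM. The step that the two limits leave unreadable from compound 1 to compound 3 cannot be read, both ends sitting at the limit of > 150000 nM in this assay, at which 2 of the 3 values shown sit. Among the compounds with values here, compound 2, `CCOC(=O)C1=Cc2ccccc2OC1(OCc1cc(-c2ccc(Br)cc2)no1)C(F)(F)F`, gives 71700 nM in this assay, the single numerical value in the set. Compound 4, `CCOC(=O)C1=Cc2ccccc2OC1(OCc1cc(-c2ccc(F)cc2)no1)C(F)(F)F`, is not yet measured; it differs from compound 2 by fluoro in place of bromo on an aromatic carbon. Within the data shown here, no measured step in the set touches this position, so nothing sets a size or direction for the change; a halogen-for-halogen exchange is taken as small. Compound 4 is expected to give about 100000 nM in this assay, within 40000 nM to 250000 nM. The step of a 1.4-fold higher number from compound 2 to compound 4 (0.14 log units; within the scatter) is estimated to lie within the scatter.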

Compound 4, half-maximal inhibitory concentration: 53500 nM
Beside the measured number, compound 4's estimate is 1.9-fold (0.27 log units) above it, and the stated range covers the measured number.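

In this assay, the change from 4-bromophenyl to 4-fluorophenyl gives a 1.3-fold lower number from compound 2 to compound 4 (0.13 log units; within the scatter), so the two halogens cannot be told apart at this position. Within the data shown here, this is the first readable step, since the step between compound 1 and compound 3 cannot be read. Nothing shown here bears on the cause of this result.

Open, as far as these compounds go, is whether an amine or a carboxylic acid in place of the halogen on this aromatic carbon would shift the number beyond the scatter. Also open, from the compounds shown here alone, is how the unsubstituted phenyl compares with compound 2 and compound 4.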